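Thiophenylmethyl for phenyl on a benzoyl thiourea nitrogen

A few compounds are considered here, and "the series" means these few. Any claim that something is new, unique, unknown or untested is made for them only; others in the source may bear on it.

Three acylthioureas have been measured in an assay on isolated protein for inhibition of polyamine deacetylase HDAC10 (Homo sapiens), read by fluorescence, tested at 100 uM; on this read-out lower numbers stand for less inhibition and higher numbers for more inhibition at the one concentration tested (going by the name of the read-out). Compound 1 `O=C(NC(=S)Nc1ccccc1)c1ccccc1F` is reported in this assay as "not active" (no number reported), with no number given. Compound 2 `O=C(NC(=S)NCc1cc(C(F)(F)F)cc(C(F)(F)F)c1)c1ccccc1` gives 10% in this assay. Compound 3 `O=C(NC(=S)Nc1ccccc1)c1ccccc1` gives 15% in this assay, the higher of the two reported numbers, though the gap to compound 2 lies within the scatter, so the two cannot be ordered.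

Compound 4 `O=C(NC(=S)NCc1cccs1)c1ccccc1` is the next member. It differs from compound 3 in one place: (thiophen-2-yl)methyl in place of phenyl on an amide-type nitrogen. Going by the values given here, no step between measured compounds matches this change, so the expectation rests on the weak inhibition seen across the series. Compound 2, which also carries a methylene-linked aromatic group on that nitrogen, gives 10%, and compound 3 gives 15%; neither suggests strong inhibition. Compound 4 is therefore expected to stay in the same low range, and the step of a number 5 percentage points lower from compound 3 to compound 4 (within the scatter) is estimated to be none beyond the scatter. The estimate for compound 4 in this assay is 10%, within a range of 0% to 25%.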

Compound 4, a percentage reported as inhibition, at one concentration (the size of the read-out at that concentration, not a potency): 47%
Compound 4: middle estimate off by 37 percentage points, on the low side, outside the stated range (above it).
By their numbers in this assay, from the lowest: compounds 2 and 3 (each within the scatter of the next); then compound 4.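

In this assay, going by these compounds alone, the earlier compounds gave only low numbers, and they did not show whether a change on the amide-type nitrogen could give a higher number; (thiophen-2-yl)methyl in place of phenyl there gives a number 32 percentage points higher from compound 3 to compound 4 (beyond the scatter), so the group on this nitrogen can matter a great deal. A methylene link alone does not account for the rise, as compound 2 also carries a methylene-linked aromatic ring on this nitrogen and gives 10%. Nothing at hand explains the rise.

The change replaces the ring and adds the methylene link in a single step, so the compounds shown leave open which of the two carries the gain. Unsubstituted benzyl or thiophen-2-yl attached directly to this nitrogen would separate them.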